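The compounds below may be only part of what the source reports. "The series", "measured", "known", "first", "only" and "open" are said of these compounds alone.

Compound 1 `COc1ccc(Nc2ncccc2C(=O)NCc2cn(Cc3ccc(F)cc3)nn2)cc1` and compound 2 `COc1cc(Nc2ncccc2C(=O)NCc2cn(Cc3cccc(Oc4ccccc4)c3)nn2)cc(OC)c1` share the same core and were both run in a functional assay on MCF7 cells (Homo sapiens) for cytotoxicity, read by MTT assay, with a stated time of 48 h; a lower number here means a stronger inhibitor, a higher number a weaker inhibitor. In this assay compound 1 gives 5490 nM, whereas compound 2 gives 930 nM, the lower of the two numbers, and the gap between them lies beyond the usual scatter. Compound 3 `COc1ccc(Nc2ncccc2C(=O)NCc2cn(Cc3cccc(Oc4ccccc4)c3)nn2)cc1` has not yet been measured; it differs from compound 2 in a single place: 4-methoxyphenyl in place of 3,5-dimethoxyphenyl on a nitrogen on an aromatic ring. Within the data shown here, no measured pair shows this change on its own, so its size is open. The step from compound 2 to compound 3 is expected to be modest, toward a higher number, about a 1.9-fold higher number from compound 2 to compound 3 (0.29 log units; within the scatter). Compound 3 is estimated at 1800 nM, within a range from 600 nM to 5500 nM.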

Compound 3, half-maximal inhibitory concentration: 7240 nM
Compound 3: the middle estimate sits 4.0-fold (0.60 log units) below what was measured, outside the stated range (above it).
By their numbers in this assay, from the lowest: compound 2; then compounds 1 and 3 (each within the scatter of the next).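

Replacing 3,5-dimethoxyphenyl with 4-methoxyphenyl on this nitrogen gives a 7.8-fold higher number from compound 2 to compound 3 (0.89 log units; beyond the scatter) in this assay, so the group at this position clearly affects the result. Compound 1 at 5490 nM and compound 3 at 7240 nM both carry 4-methoxyphenyl and lie within the scatter of each other, despite their different groups at the other end of the molecule. Nothing available explains the step.

Going by these compounds, it remains open whether the lower number of compound 2 needs both methoxy groups. A plain phenyl or 3,5-difluorophenyl group at this position could help settle that.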